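Swapping a chlorothiophene for a dimethylthiophene on the sulfoxide arm

The source may report more compounds than this note shows. Statements on the series, on what has been measured and on what is new or still open speak of the compounds shown alone.

Compound 2 `[O-][S+](Cc1ccc(Cl)s1)C(c1ccccc1)c1ccccc1` is measured in an assay on HEK293 cells for inhibition of sodium-dependent dopamine transporter (Homo sapiens), read by scintillation counting, with stated times of 5 min and 1 min (a lower number here means a stronger inhibitor, a higher number a weaker inhibitor), at 12800 nM. Among the three compounds measured, compound 2 stands second highest: compound 3 `[O-][S+](Cc1cccs1)C(c1ccc(Cl)cc1)c1ccc(Cl)cc1` gives 7200 nM, a gap within the scatter, while compound 1 `COC1NN=C(C[S+]([O-])C(c2ccccc2)c2ccccc2)S1` gives 108000 nM. Within the data shown here, the step of an 8.4-fold lower number from compound 1 to compound 2 (0.93 log units; beyond the scatter) is the only measured change at this position. Compound 4 `Cc1scc(C[S+]([O-])C(c2ccccc2)c2ccccc2)c1C` differs from compound 2 by 4,5-dimethylthiophen-3-yl in place of 5-chlorothiophen-2-yl on a saturated chain carbon bound to a sulfur. That measured step exchanged a non-aromatic ring for an aromatic one; here both rings are thiophenes and only their substituents move, so the data give no direct guide. The number for compound 4 is therefore expected to stay close, with a step of a 1.3-fold lower number from compound 2 to compound 4 (0.11 log units; within the scatter) inside the scatter, at an estimated 10000 nM ranging from 3000 nM to 40000 nM.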

Compound 4, half-maximal inhibitory concentration: 284000 nM
For compound 4 the middle estimate is 28-fold (1.45 log units) below the measured one; measured number outside the range, above it.
By their numbers in this assay, from the lowest: compounds 3 and 2 (each within the scatter of the next); then compound 1; then compound 4.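

In this assay this position proves sensitive to what the thiophene carries, not merely to the presence of a thiophene (a 22-fold higher number from compound 2 to compound 4 (1.35 log units; beyond the scatter)). An aromatic ring alone does not bring the lower number either, as the new thiophene reverses the direction of the earlier ring swap (a 2.6-fold higher number from compound 1 to compound 4 (0.42 log units; beyond the scatter)). Nothing available explains this jump. Going by these compounds, the chlorine, the methyl groups and the ring's point of attachment all changed in one step, and which of them matters stays open. So does the effect of an amine or a carboxylic acid in this place.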